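Working notes on a tert-butoxycarbonyl removal step

The source may hold more compounds than are shown below. What is called first, only, known or untested is meant among the compounds shown, and "the series" means these compounds.

Measured so far, in a functional assay on RAW264.7 cells (Mus musculus) for inhibition; a lower number here means a stronger inhibitor, a higher number a weaker inhibitor:
- compound 1, `CC(C)(C)OC(=O)N(Cc1ccco1)C(=O)c1ccc(Cn2c(=O)c3ccccc3[s+]2[O-])cc1`, gives 68000 nM
- compound 2, `O=C(NCc1ccco1)c1ccc(Cn2c(=O)c3ccccc3[s+]2[O-])cc1`, gives 23300 nM
- compound 3, `CC(C)(C)OC(=O)N(Cc1ccco1)C(=O)c1ccc(Cn2oc3ccccc3c2=O)cc1`, gives 6690 nM

Two changes have been made from compound 1. The first is hydrogen in place of tert-butoxycarbonyl on an amide-type nitrogen, which gave a 2.9-fold lower number from compound 1 to compound 2 (0.47 log units; beyond the scatter). The second is the change of core, (a group of 10 heavy atoms (7 carbon, 1 nitrogen, 2 oxygen; one five-membered aromatic ring with 2 hetero atoms, one six-membered aromatic ring of carbon only) in place of a group of 11 heavy atoms (7 carbon, 1 nitrogen, 2 oxygen, 1 sulfur; one five-membered aromatic ring with 2 hetero atoms, one six-membered aromatic ring of carbon only), on a saturated chain carbon bound to an aromatic carbon), which gave a 10-fold lower number from compound 1 to compound 3 (1.01 log units; beyond the scatter). Compound 3 therefore stands lowest of the three; its nearest neighbour is compound 2, and compound 1 is furthest from it. Among the compounds with values here, compounds 2 and 3 are not a measured pair, and no step between them is counted here; their two values simply show that compound 3 lies lower than compound 2.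

The unmeasured member is compound 4, `O=C(NCc1ccco1)c1ccc(Cn2oc3ccccc3c2=O)cc1`. It is made from compound 3 by hydrogen in place of tert-butoxycarbonyl on an amide-type nitrogen. The place of this change is the same word for word as in the change from compound 1 to compound 2, so the two changes are the same, only on different cores. Its effect has been seen once, in this assay, as the step from compound 1 to compound 2.

Within the data shown here, for compound 4 a step of a 2.9-fold lower number from compound 3 to compound 4 (0.46 log units; beyond the scatter) in this assay is expected, resting on the single earlier step of a 2.9-fold lower number from compound 1 to compound 2 (0.47 log units; beyond the scatter) and on the assumption that the two cores respond alike to this change, which nothing here confirms. Compound 4 is accordingly estimated at 2300 nM, in the range 900 nM to 6000 nM.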

Compound 4, half-maximal inhibitory concentration: 49300 nM
Estimate against measurement, compound 4: 21-fold (1.33 log units) below, and the stated range ends below it.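

In this assay, hydrogen in place of tert-butoxycarbonyl on an amide-type nitrogen gave a 7.4-fold higher number from compound 3 to compound 4 (0.87 log units; beyond the scatter), so the change does not act in the same direction on the two cores, and its effect on one core cannot be carried over to the other in this series: the same change on two cores in this assay, a 2.9-fold lower number (0.47 log units; beyond the scatter) from compound 1 to compound 2 and a 7.4-fold higher number (0.87 log units; beyond the scatter) from compound 3 to compound 4, 22-fold (1.33 log units) apart, beyond the scatter of two such steps

Within these four compounds, the outcome of this change therefore depends on the core it is made on, and a single step on one core gives no usable guide to the other. Within the data shown here, each core contributes only one step, however, so neither direction can be called typical, and the numbers do not show why the two cores part ways or whether the same reversal would hold for any other change on this nitrogen.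

Open, as far as these compounds go, is whether an acetyl or a methyl group on the amide-type nitrogen would follow hydrogen or tert-butoxycarbonyl on each core. Also open, from the compounds shown here alone, is whether the opposite directions persist when the saturated chain on that nitrogen is replaced by a plain ethyl group or a longer alkyl chain.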